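Thiophen-2-yl in Place of 4-(Trifluoromethyl)phenyl: What to Expect

The source may hold more compounds than are shown below. What is called first, only, known or untested is meant among the compounds shown, and "the series" means these compounds.

Measured in a functional assay on PC-3 cells (Homo sapiens) for antiproliferative activity, read by MTT assay; a higher number here means a weaker inhibitor, a lower number a stronger inhibitor:
compound 1, `Cn1c(=O)c(=O)n(C2CCCC2)c2nc(N/N=C/c3ccccc3)ncc21`, gives 48200 nM
compound 2, `Cn1c(=O)c(=O)n(C2CCCC2)c2nc(N/N=C/c3ccc(O)cc3)ncc21`, gives > 100000 nM, a limit of the assay
compound 3, `Cn1c(=O)c(=O)n(C2CCCC2)c2nc(N/N=C/c3ccc(C(F)(F)F)cc3)ncc21`, gives 23600 nM

Compound 3 holds the lowest of the two numbers in this assay. The nearest number belongs to compound 1, and the step between them is a 2.0-fold lower number from compound 1 to compound 3 (0.31 log units; beyond the scatter), so the trifluoromethyl on the aromatic carbon goes with a lower number. Compound 2 sits at a limit only: the limit of > 100000 nM in this assay, at which 1 of the 3 values shown sits. Against that limit, the step of an at least 4.2-fold lower number from compound 2 to compound 3 (0.62 log units; beyond the scatter) is the largest shown, and an at least 2.0-fold higher number from compound 1 to compound 2 (0.31 log units; beyond the scatter) shows the hydroxy pushing the number up and out of range.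

Compound 4, `Cn1c(=O)c(=O)n(C2CCCC2)c2nc(N/N=C/c3cccs3)ncc21`, differs from compound 3 by thiophen-2-yl in place of 4-(trifluoromethyl)phenyl on a carbon with a double bond to nitrogen. Among the measured compounds shown here, none of the measured steps exchanges the whole ring; they only change a group on the phenyl. The loss of the trifluoromethyl is the part that the data speak to, and from compound 3 back to compound 1 it gave a modest rise. A thiophen-2-yl is not covered by any step, so the expectation leans on compound 1 alone.

Compound 4 is therefore expected to give about 45000 nM, somewhere between 15000 nM and 100000 nM. That estimate amounts to an expected 1.9-fold higher number from compound 3 to compound 4 (0.28 log units; within the scatter).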

Compound 4, half-maximal inhibitory concentration: 75600 nM
The estimate for compound 4 lay 1.7-fold (0.23 log units) below the measured number; the measured number falls inside the stated range.
By their numbers in this assay, from the lowest: compound 3; then compounds 1 and 4 (each within the scatter of the next). At a limit, above all of these: compound 2.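

In this assay, among the compounds shown here, the first exchange of the whole ring at this position, on the carbon with a double bond to nitrogen, shows that thiophen-2-yl can replace phenyl with no step beyond the scatter: a 1.6-fold higher number from compound 1 to compound 4 (0.20 log units; within the scatter). The compounds with a measured number therefore do not separate by ring size here, as the five-membered thiophen-2-yl and the six-membered phenyl stand within the scatter of each other, while the trifluoromethyl on the phenyl remains what sets compound 3 apart: a 3.2-fold higher number from compound 3 to compound 4 (0.51 log units; beyond the scatter). Compound 2 gives only a limit, and an at least 1.3-fold lower number from compound 2 to compound 4 (0.12 log units; that floor lies within the scatter) has a floor too small to place the two compounds in an order: the limit of > 100000 nM in this assay, at which 1 of the 4 values shown sits.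

The compounds shown leave open whether a trifluoromethyl on the thiophen-2-yl would bring the same step as on the phenyl, since this ring has so far been seen only without a further group. They also leave open how other rings, such as furan-2-yl or pyridin-2-yl, or other groups on the phenyl, such as chlorine, methoxy or an amine, would fall in this assay.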